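This account rests on a few compounds, and the source may have more. Where it says the series, first, only, none or still open, it means among the compounds named here.

Compound 1 `N#CC1=C(N)Oc2c(c3nc4ccccc4nc3c3ccccc23)C12C(=O)N(Cc1cnnn1-c1ccc(F)cc1)c1ccccc12`. In a functional assay on HepG2 cells (Homo sapiens) for antiproliferative activity, read by MTT assay, with a stated time of 48 h (a lower number here means a stronger inhibitor, a higher number a weaker inhibitor), compound 1 is reported only as a limit, > 50000 nM.
Compound 2 `N#CC1=C(N)Oc2c(c3nc4ccccc4nc3c3ccccc23)C12C(=O)N(Cc1cnnn1-c1ccccc1Cl)c1ccccc12`. In this assay compound 2 is likewise reported only as a limit, > 50000 nM.
Compound 3 `N#CC1=C(N)Oc2c(c3nc4ccccc4nc3c3ccccc23)C12C(=O)N(Cc1cnnn1-c1cccc(Cl)c1)c1ccccc12`. In this assay compound 3 is again reported only as a limit, > 50000 nM.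

Compound 2 thus stands where every measured member of the series stands: at the limit, not at a number. The steps between the measured compounds, a step that the two limits leave unreadable from compound 1 to compound 2, a step that the two limits leave unreadable from compound 1 to compound 3 and a step that the two limits leave unreadable from compound 2 to compound 3, are each unreadable, since two limits bound every pair. This is summed up by the limit of > 50000 nM in this assay, at which 3 of the 3 values shown sit, which leaves no order among compounds 1, 2 and 3.

Compound 4 `N#CC1=C(N)Oc2c(c3nc4ccccc4nc3c3ccccc23)C12C(=O)N(Cc1cnnn1-c1cccc(Br)c1)c1ccccc12` is not yet measured. It differs from compound 2 by 3-bromophenyl in place of 2-chlorophenyl on an aromatic nitrogen. The closest measured step, from compound 2 to compound 3, moves the halogen to the same ring position and is unreadable; the step from compound 1 to compound 3 is unreadable too. Nothing measured argues for a gain, so the expected step in this assay, a step that the limit leaves unreadable from compound 2 to compound 4, is none beyond the scatter, with the result most likely reported as a limit again. Compound 4 is estimated at 80000 nM, in the range 30000 nM to 300000 nM.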

Compound 4, half-maximal inhibitory concentration: > 50000 nM
Compound 4: a limit, no number; the forecaster's own chance of this, stated with the estimate: 85%; the middle value lies beyond the limit too.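

Compound 4 is reported in this assay only as a limit, > 50000 nM. Its steps to compound 1, compound 2 and compound 3 cannot be read, because all of them rest on the same limit: the limit of > 50000 nM in this assay, at which 4 of the 4 values shown sit. The compounds shown leave open whether any phenyl substituent gives a number in this assay, and how these compounds rank.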